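Chloro on the shared core: cytotoxicity outlook for compound 3

This account rests on a few compounds, and the source may have more. Where it says the series, first, only, none or still open, it means among the compounds named here.

Measured so far:
compound 1 `O=c1nc2ccc(Cl)cn2cc1Cc1ccc(F)cc1C(F)(F)F`: > 1000000 nM
compound 2 `O=c1nc2ccccn2cc1Cc1ccc(F)cc1`: > 1000000 nM

Both measured compounds were run in a functional assay on HepG2 cells (Homo sapiens) for cytotoxicity, read by MTT assay, with a stated time of 24 h; on this read-out lower numbers stand for stronger inhibition and higher numbers for weaker inhibition. Compound 1 gives > 1000000 nM, which is a limit of the assay and not a number. Compound 2 gives > 1000000 nM in this assay, likewise a limit rather than a measured number. Compound 2 therefore stands at the limit, and so does every other value shown: the limit of > 1000000 nM in this assay, at which 2 of the 2 values shown sit. Going by the values given here, no step between two measured compounds that differ in one place is available, so nothing about the size of any single change has been observed directly.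

The next compound, compound 3 `O=c1nc2ccc(Cl)cn2cc1Cc1ccc(F)cc1`, differs from compound 2 by chloro in place of hydrogen on an aromatic carbon. Compound 1 carries chloro at that same place on the shared core and sits at the limit in this assay. With both values shown at the limit, no change beyond the usual scatter is expected from this exchange in this assay. For compound 3 the expected step is a step that the limit leaves unreadable from compound 2 to compound 3. Compound 3 is expected at 1500000 nM, in the range 500000 nM to 5000000 nM, most likely reported again only as a limit.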

Compound 3, half-maximal inhibitory concentration: > 1000000 nM
Compound 3 was reported as a limit; the forecaster's own chance of this, stated with the estimate: 85%; the middle value does not contradict the limit.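

In this assay no step can be read from compound 2 or from compound 1 to compound 3, as all three values are limits of the assay and not numbers: the limit of > 1000000 nM in this assay, at which 3 of the 3 values shown sit.

The compounds shown leave open what size of effect, if any, chloro in place of hydrogen on the shared core has on cytotoxicity.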